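This account rests on a few compounds, and the source may have more. Where it says the series, first, only, none or still open, it means among the compounds named here.

Compound 2 `COc1cccc(-c2c(C)n(Cc3c(F)cccc3F)c(=O)n([C@H](C)CNCc3cccc(F)c3)c2=O)c1` is the stronger of the two measured compounds in an assay on HEK293 cells for binding affinity to Gonadotropin-releasing hormone receptor (Homo sapiens); a lower number here means a stronger inhibitor, a higher number a weaker inhibitor. In this assay compound 2 gives 85 nM, whereas compound 1 `COc1cccc(-c2c(C)n(Cc3c(F)cccc3F)c(=O)n([C@@H](C)CNCC(C)C)c2=O)c1` gives 1200 nM. Among the compounds with values here, the only measured step, a 14-fold lower number from compound 1 to compound 2 (1.15 log units; beyond the scatter), replaced the isobutyl arm on the amine nitrogen with a 3-fluorobenzyl arm and brought a large gain.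

Compound 3 `COc1cccc(-c2c(C)n(Cc3c(F)cccc3F)c(=O)n([C@H](C)CNCc3ccc(F)cc3)c2=O)c1` differs from compound 2 by 4-fluorophenyl in place of 3-fluorophenyl on a saturated chain carbon bound to an amine nitrogen. Within the data shown here, the one measured step does bear on this region, since it shows that the fluorobenzyl arm on the amine is a place where this assay responds strongly, but it compares a benzyl arm with an alkyl arm and says nothing about moving the fluorine from one ring position to another. Among the measured compounds shown here, there is thus no measured step that tells whether the 4-fluorophenyl will read higher or lower than the 3-fluorophenyl. The expectation is therefore a step of a 1.2-fold higher number from compound 2 to compound 3 (0.07 log units; within the scatter), that is, no change beyond the scatter in either direction. Compound 3 is expected to give an estimated 100 nM, within a range of 35 nM to 300 nM.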

Compound 3, inhibition constant: 250 nM
Compound 3: middle estimate off by 2.5-fold (0.40 log units), on the low side; the range from low to high includes it.
By their numbers in this assay, from the lowest: compound 2; then compound 3; then compound 1.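

In this assay the ring position of the fluorine matters: 4-fluorophenyl in place of 3-fluorophenyl on a saturated chain carbon bound to an amine nitrogen gives a 2.9-fold higher number from compound 2 to compound 3 (0.47 log units; beyond the scatter) and thus a modest loss, with nothing else in the structure changed. The 4-fluorobenzyl arm still reads better than the isobutyl arm, with a 4.8-fold lower number from compound 1 to compound 3 (0.68 log units; beyond the scatter) as a modest gain, so both fluorobenzyl arms shown give lower numbers than the isobutyl arm, although the 3-fluorobenzyl arm gives the lowest number of the three. Nothing available here accounts for the difference between the two fluorine positions.

The compounds shown leave open how an unsubstituted benzyl arm, a 2-fluorobenzyl arm or a 3-chlorobenzyl arm would compare with the 3-fluorobenzyl arm of compound 2. They also leave open whether a 3-methoxybenzyl arm, or a longer chain such as a 2-phenylethyl arm on the amine nitrogen, would hold or improve on that number, so the preference for the 3-fluorobenzyl arm rests on these three compounds alone.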